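Ethoxy for Methyl on the Chain of Compound 3

The compounds below may be only part of what the source reports. "The series", "measured", "known", "first", "only" and "open" are said of these compounds alone.

Compound 1 `COCC(Nc1nnc(-c2ccc(OC)cc2)o1)[C@H]1CC[C@@H](c2ccnc3ccc(F)cc32)CC1`: 44 nM
Compound 2 `C[C@@H](c1nc2ncc(Cl)cc2[nH]1)[C@H]1CC[C@@H](c2ccnc3ccc(F)cc32)CC1`: 36 nM
Compound 3 `CCC(Nc1nnc(-c2ccc(OC)cc2)o1)[C@H]1CC[C@@H](c2ccnc3ccc(C(F)(F)F)cc32)CC1`: 6 nM

Of the compounds shown here, three have been measured in an assay on tissue (M109 cells) for inhibition of Indoleamine 2,3-dioxygenase 1 (Mus musculus), read by fluorescence, with a stated time of 18 h; a higher number here means a weaker inhibitor, a lower number a stronger inhibitor. Compound 3 gives 6 nM, the lowest number of the three, and its distance from both compound 2 and compound 1 lies beyond the usual scatter, so it is the strongest inhibitor among them. For the measured compounds named here, compound 1 and compound 2 differ from compound 3 in more than one place, so no single step between measured compounds is available.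

Compound 4 `CCOCC(Nc1nnc(-c2ccc(OC)cc2)o1)[C@H]1CC[C@@H](c2ccnc3ccc(C(F)(F)F)cc32)CC1` is not yet measured. It differs from compound 3 by ethoxy in place of methyl on a saturated chain carbon, two bonds along the chain from a nitrogen on an aromatic ring and a saturated ring carbon. Going by the values given here, no measured pair shows this change on its own; the only guide is that compound 1, which carries an oxygen in its chain, gives 44 nM while also carrying a different quinoline substituent.

Compound 4 is therefore expected to lose a little against compound 3, with a step of a 2.0-fold higher number from compound 3 to compound 4 (0.30 log units; within the scatter) in this assay, though the step could still fall within the scatter. The estimate for compound 4 in this assay is 12 nM, with a range from 4 nM to 40 nM.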

Compound 4, half-maximal inhibitory concentration: 57 nM
Compound 4: the middle estimate sits 4.8-fold (0.68 log units) below what was measured; measured number outside the range, above it.
By their numbers in this assay, from the lowest: compound 3; then compounds 2, 1 and 4 (each within the scatter of the next).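

For the compounds shown here, the first single change that can be read at this position raises the number: in this assay, ethoxy in place of methyl on the saturated chain carbon gives a 9.5-fold higher number from compound 3 to compound 4 (0.98 log units; beyond the scatter). The earlier compounds shown here could not show this, since compound 1 also carries an oxygen in its chain but differs from compound 3 in more than one place, whereas here only the chain differs. Nothing available bears on why this change raises the number.

The compounds shown do not separate the effect of the chain oxygen from that of the added length, which a butyl chain in place of the ethoxymethyl would address. Going by these compounds, whether an amine at this position would be tolerated, and whether the same step holds on the core of compound 1, also stays open.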